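Dropping the Chloro from Compound 2's Hydrazone Ring

This account rests on a few compounds, and the source may have more. Where it says the series, first, only, none or still open, it means among the compounds named here.

Measured compounds:
- compound 1 `CCCSc1nc(N/N=C(\C)c2ccccc2O)c2nnn(Cc3ccc(Cl)cc3)c2n1`: 42600 nM
- compound 2 `CCCSc1nc(N/N=C/c2ccccc2Cl)c2nnn(Cc3ccccc3)c2n1`: 13800 nM
- compound 3 `CCCSc1nc(N/N=C(\C)c2ccccc2O)c2nnn(Cc3ccc(O)cc3)c2n1`: 9520 nM

All three were tested in a functional assay on MCF7 cells (Homo sapiens) for antiproliferative activity, read by MTT assay, with a stated time of 72 h; on this read-out lower numbers stand for stronger inhibition and higher numbers for weaker inhibition. Compound 2 stands second highest of the three numbers: compound 3 lies within the scatter of it, while compound 1 sits beyond the scatter at a higher number. Among the compounds with values here, the one step that can be read between single-point changes is a 4.5-fold lower number from compound 1 to compound 3 (0.65 log units; beyond the scatter).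

The unmeasured compound 4 `CCCSc1nc(N/N=C/c2ccccc2)c2nnn(Cc3ccccc3)c2n1` is reached from compound 2 by hydrogen in place of chloro on an aromatic carbon. This change sits on the ring that hangs from the hydrazone, not on the benzyl ring where the step from compound 1 to compound 3 was made, and it removes a chloro rather than swapping it for hydroxy. Within the data shown here, no measured pair therefore bears on it directly; the only guidance is that a change on a distant ring moved the number by a modest amount. With nothing to point a direction, the step from compound 2 to compound 4 is expected to stay near or just beyond the scatter, leaning toward a somewhat higher number: a 1.4-fold higher number from compound 2 to compound 4 (0.16 log units; within the scatter). Compound 4 is accordingly estimated at 20000 nM, with a range from 7000 nM to 60000 nM.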

Compound 4, half-maximal inhibitory concentration: > 64000 nM
Compound 4 gave a limit, no number; the forecaster's own chance of this, stated with the estimate: 10%; at least 3.2-fold (0.50 log units) between middle value and limit.
By their numbers in this assay, from the lowest: compounds 3 and 2 (each within the scatter of the next); then compound 1. At a limit, above all of these: compound 4.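

In this assay, taking the chloro off the 2-chlorophenyl ring has a clear effect: an at least 4.6-fold higher number from compound 2 to compound 4 (0.66 log units; beyond the scatter). Within the data shown here, until now, the only readable step was on the benzyl ring, a 4.5-fold lower number from compound 1 to compound 3 (0.65 log units; beyond the scatter), so this is the first sign that the number also responds to a change on the ring hanging from the hydrazone, at a place ortho to a large group, where chloro goes with a lower number than hydrogen. Compound 4 gives > 64000 nM, which is a limit and not a number, so the step has a known minimum but no known size, and the reading sits at the end of the measured range: the limit of > 64000 nM in this assay, at which 1 of the 4 values shown sits.

On these data alone, it remains open whether chloro is special at this place or whether another group there, such as a methyl, a methoxy or an amine, would keep the number as low. Compound 1 and compound 3 also carry a hydroxy on this ring, but they differ from compound 2 in more than one place, and the steps that would link them cannot be read.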